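A few compounds are considered here, and "the series" means these few. Any claim that something is new, unique, unknown or untested is made for them only; others in the source may bear on it.

In a functional assay on HCC827 cells (Homo sapiens) for cytotoxicity, read by MTT assay, with a stated time of 72 h (a lower number here means a stronger inhibitor, a higher number a weaker inhibitor), compound 1 `C#Cc1cccc(Nc2nc3cnc(Nc4ccc(N5CCN(C)CC5)cc4)nc3n2C2CCCC2)c1` gives < 0.01 nM as a limit of the assay and not as a number. On these data alone, its exact place stays open (the limit of < 0.01 nM in this assay, at which 1 of the 3 values shown sits) and steps from it can be read only in part. Compound 2 `CN1CCN(c2ccc(Nc3ncc4nc(Nc5ccc(Br)cc5F)n(C5CCCC5)c4n3)cc2)CC1` with 4-bromo-2-fluorophenyl gives 2.3 nM and compound 3 `CN1CCN(c2ccc(Nc3ncc4nc(Nc5cc(Cl)ccc5Cl)n(C5CCCC5)c4n3)cc2)CC1` with 2,5-dichlorophenyl gives 0.01 nM in the same read-out.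

Compound 4 `CN1CCN(c2ccc(Nc3ncc4nc(Nc5cccc(NC(=O)c6ccccc6)c5)n(C5CCCC5)c4n3)cc2)CC1` carries benzamido in place of ethynyl on an aromatic carbon and otherwise matches compound 1. Within the data shown here, no measured step changes that group alone. The nearest evidence is the exchange of the whole aryl group on the nitrogen, which gave an at least 230-fold higher number from compound 1 to compound 2 (2.36 log units; beyond the scatter) and then a 230-fold lower number from compound 2 to compound 3 (2.36 log units; beyond the scatter) as large steps in opposite directions. The third exchange gave a number no lower from compound 1 to compound 3 (the limit leaves the size open) with no readable size. These three compounds show that changes in this aryl group can be large, but they do not fix the outcome for benzamido. With compound 2 at 2.3 nM as a guide, a large move to a higher number is expected, and the estimated step is an at least 50-fold higher number from compound 1 to compound 4 (1.69 log units; beyond the scatter) on that basis. In this assay compound 4 is expected at 0.5 nM with an estimated range from 0.02 nM to 15 nM as its likely span.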

Compound 4, half-maximal inhibitory concentration: 15 nM
For compound 4 the middle estimate is 30-fold (1.48 log units) below the measured one; low and high end bracket the measured number.
By their numbers in this assay, from the lowest: compound 3; then compound 2; then compound 4.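

In this assay, among these compounds, a change confined to the substituent on an aromatic carbon, meta to a large group, gives an at least 1500-fold higher number from compound 1 to compound 4 (3.17 log units; beyond the scatter); the earlier steps replaced the whole aryl group on the nitrogen, so this is the first reading of this position on its own. With 9 heavy atoms entering for 2, and a six-membered aromatic ring of carbon only and an amide coming in together, size, ring and amide all change at once, and the step cannot be assigned to any one of them. Compound 1 stands at a limit of the assay and not at a number, so the step gives only a lower bound on the size of the change: the limit of < 0.01 nM in this assay, at which 1 of the 4 values shown sits.

Still open, on these data alone, is whether the amide or the added ring accounts for the rise, a question that acetamido, an amine such as aminomethyl, or a nitrile on the same aromatic carbon would help to settle. Also open, as far as these compounds go, is whether a benzamido group at this position would behave the same way with the cyclopentyl group or the methylpiperazine of the shared core replaced.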